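Replacing a Halogen by Phenyl on a Pyridine Ring

The source may hold more compounds than are shown below. What is called first, only, known or untested is meant among the compounds shown, and "the series" means these compounds.

Compound 2 `Fc1ccc(C2=CC3CNCC(C2)C3)cn1` is measured in an in vitro assay on SH-EP1 cells for displacement of a labelled ligand from Neuronal acetylcholine receptor; alpha4/beta2 (Homo sapiens) (on this read-out higher numbers stand for weaker inhibition and lower numbers for stronger inhibition), at 0.4 nM. Compound 1 `Clc1ccc(C2=CC3CNCC(C2)C3)cn1` gives 0.4 nM in this assay, and the step from chloro to fluoro shows no change at the digits printed from compound 1 to compound 2 (within the scatter), so compound 2 stands level with compound 1. Compound 3 `C1=C(c2ccc(-c3ccccc3)nc2)CC2CNCC1C2` differs from compound 2 by phenyl in place of fluoro on an aromatic carbon. Within the data shown here, the one measured step only swaps two halogens at this position, so nothing measured speaks to a phenyl there. Compound 3 is therefore estimated at 5 nM, between 0.8 nM and 30 nM, a step of a 13-fold higher number from compound 2 to compound 3 (1.10 log units; beyond the scatter) expected with wide uncertainty.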

Compound 3, inhibition constant: 105 nM
Estimate against measurement, compound 3: 21-fold (1.32 log units) below; measured number above the stated range.
By their numbers in this assay, from the lowest: compounds 1 and 2 (each within the scatter of the next); then compound 3.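

The two halogens suggested that this position tolerates change, but that holds only for the swap between them: phenyl brings a 260-fold higher number from compound 2 to compound 3 (2.42 log units; beyond the scatter) and likewise a 260-fold higher number from compound 1 to compound 3 (2.42 log units; beyond the scatter) and so much weaker inhibition. On this position, then, replacing a single halogen atom with a six-carbon aromatic ring is far from a neutral change. No evidence given here explains this loss. Going by these compounds, it remains open whether a methyl, a methoxy or an amine at this position would stay level with compound 2, and how phenyl would fare elsewhere on the pyridine ring.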